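The compounds below may be only part of what the source reports. "The series", "measured", "known", "first", "only" and "open" are said of these compounds alone.

Measured compounds in the series:
- compound 1 `Nc1ccccc1-c1cnc(C(=O)CCCCCCc2ccccc2)o1`: 750 nM
- compound 2 `O=C(CCCCCCc1ccccc1)c1ncc(-c2ccccc2F)o1`: 110 nM
- compound 3 `O=C(CCCCCCc1ccccc1)c1ncc(-c2ccc([N+](=O)[O-])cc2)o1`: 50 nM

All three were run in an assay (Rattus norvegicus) for inhibition of Fatty-acid amide hydrolase 1 (Homo sapiens); on this read-out lower numbers stand for stronger inhibition and higher numbers for weaker inhibition. Compound 1 gives the highest number of the three, with 750 nM. Compound 2 sits nearest to it, a 6.8-fold lower number from compound 1 to compound 2 (0.83 log units; beyond the scatter). Compound 3 is furthest, a 15-fold lower number from compound 1 to compound 3 (1.18 log units; beyond the scatter). Between the two lower compounds the step is a 2.2-fold lower number from compound 2 to compound 3 (0.34 log units; beyond the scatter).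

Compound 4 `Cc1ccc(-c2cnc(C(=O)CCCCCCc3ccccc3)o2)nc1` is not yet measured. Its change from compound 1 is:
5-methylpyridin-2-yl in place of 2-aminophenyl on an aromatic carbon

Both measured steps out of compound 1 replace the 2-aminophenyl group, and both give a lower number in this assay: a 6.8-fold lower number from compound 1 to compound 2 (0.83 log units; beyond the scatter) and a 15-fold lower number from compound 1 to compound 3 (1.18 log units; beyond the scatter). Neither of them introduces the 5-methylpyridin-2-yl group, so how far compound 4 moves is open. Because of a 6.8-fold lower number from compound 1 to compound 2 (0.83 log units; beyond the scatter) and a 15-fold lower number from compound 1 to compound 3 (1.18 log units; beyond the scatter) a lower number than compound 1 is expected for compound 4, of a modest size. The expected step is a 5.0-fold lower number from compound 1 to compound 4 (0.70 log units; beyond the scatter). For compound 4 the estimate in this assay is 150 nM, with a range from 50 nM to 450 nM.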

Compound 4, inhibition constant: 2.8 nM
Compound 4: the middle estimate sits 54-fold (1.73 log units) above what was measured; measured number below the stated range.
By their numbers in this assay, from the lowest: compound 4; then compound 3; then compound 2; then compound 1.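

At this position, on an aromatic carbon next to the ring oxygen, the change of ring type reaches well beyond anything the carbon-only aromatic rings showed in this assay. The 5-methylpyridin-2-yl group improves on the 2-aminophenyl group of the same heavy-atom count (a 270-fold lower number from compound 1 to compound 4 (2.43 log units; beyond the scatter)), and it also clearly outdoes the 2-fluorophenyl group (a 39-fold lower number from compound 2 to compound 4 (1.59 log units; beyond the scatter)) and the 4-nitrophenyl group (an 18-fold lower number from compound 3 to compound 4 (1.25 log units; beyond the scatter)), so compound 4 is the most potent of the four. No measurement shown accounts for this gain.

The compounds shown leave open how much of the gain belongs to the ring nitrogen and how much to the methyl group. An unsubstituted pyridin-2-yl group and a methylphenyl group at this position would separate the two.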